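The source may report more compounds than this note shows. Statements on the series, on what has been measured and on what is new or still open speak of the compounds shown alone.

Compound 3 `CS(=O)(=O)Nc1ccc(-n2cc(-c3ccccc3)nn2)cc1Oc1ccccc1` is the point of departure here. Within the data shown here, in a functional assay on DU-145 cells (Homo sapiens) for inhibition, read by MTT assay, with a stated time of 48 h (a lower number here means a stronger inhibitor, a higher number a weaker inhibitor), compound 3 gives 14200 nM, the highest of the three numbers measured so far. Compound 1 `Cc1ccc(OCc2cn(-c3ccc(NS(C)(=O)=O)c(Oc4ccccc4)c3)nn2)cc1` gives 8200 nM in this assay, and compound 2 `CS(=O)(=O)Nc1ccc(-n2cc(COc3ccc([N+](=O)[O-])cc3)nn2)cc1Oc1ccccc1` gives 7200 nM. Both of these lie within the scatter of compound 3, as the steps of a 1.7-fold higher number from compound 1 to compound 3 (0.24 log units; within the scatter) and a 2.0-fold higher number from compound 2 to compound 3 (0.29 log units; within the scatter) show, so none of the three can be called a stronger or weaker inhibitor than the others. The step that only exchanges one substituent on an aromatic ring for another, a 1.1-fold lower number from compound 1 to compound 2 (0.06 log units; within the scatter), also stays within the scatter.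

Compound 4 `Cc1ccc(-c2cn(-c3ccc(NS(C)(=O)=O)c(Oc4ccccc4)c3)nn2)cc1` differs from compound 3 by methyl in place of hydrogen on an aromatic carbon. The step from compound 1 to compound 2 is the nearest guide, since it too exchanges one small group for another on a six-membered aromatic ring of carbon only, and it moved the number by nothing beyond the scatter. Among the measured compounds shown here, no measured pair exchanges hydrogen for methyl, so the direction of any shift is unknown. Compound 4 is therefore expected to give much the same number as compound 3, an expected step of a 1.2-fold lower number from compound 3 to compound 4 (0.07 log units; within the scatter). The estimate for compound 4 in this assay is 12000 nM, with a range from 5000 nM to 28000 nM.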

Compound 4, half-maximal inhibitory concentration: 11200 nM
For compound 4 the middle estimate is 1.1-fold (0.03 log units) above the measured one; the measured number falls inside the stated range.
By their numbers in this assay, from the lowest: compounds 2, 1, 4 and 3 (each within the scatter of the next).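

The pair of compound 3 and compound 4 is the only one shown that exchanges hydrogen for methyl, and at this place, on a six-membered aromatic ring of carbon only and para to a large group, the exchange gives no readable change in this assay (a 1.3-fold lower number from compound 3 to compound 4 (0.10 log units; within the scatter)). Among these compounds, the 4-methylphenyl group also stays within the scatter of the two larger groups, (4-methylphenoxy)methyl (a 1.4-fold higher number from compound 1 to compound 4 (0.14 log units; within the scatter)) and (4-nitrophenoxy)methyl (a 1.6-fold higher number from compound 2 to compound 4 (0.19 log units; within the scatter)), so all four groups seen at this place so far give numbers that cannot be told apart. Nothing available here bears on what lies behind these numbers.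

Still open, on these data alone, is whether a different kind of group on that ring, such as an amine or a carboxylic acid in place of the methyl, would move the number beyond the scatter. Also open, as far as these compounds go, is whether a change elsewhere on the shared core, rather than at this place, would separate these compounds in this cell assay.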